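Swapping the aryl group on the carbonyl of a furan-bearing core

The compounds below may be only part of what the source reports. "The series", "measured", "known", "first", "only" and "open" are said of these compounds alone.

Measured compounds and their values in a functional assay on PC-3 cells (Homo sapiens) for cytotoxicity, read by MTT assay, with a stated time of 48 h; on this read-out lower numbers stand for stronger inhibition and higher numbers for weaker inhibition:
- compound 1, `COc1cc(-c2nnc3n2NC(c2ccco2)C(C(=O)c2ccc(F)c(F)c2)S3)cc(OC)c1OC`, gives 36000 nM
- compound 2, `COc1cc(-c2nnc3n2NC(c2ccco2)C(C(=O)c2ccc(C(F)(F)F)cc2)S3)cc(OC)c1OC`, gives 77500 nM
- compound 3, `COc1cc(-c2nnc3n2NC(c2ccco2)C(C(=O)c2ccc(-c4ccccc4)cc2)S3)cc(OC)c1OC`, gives 45900 nM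

All three share one core and differ only in the aryl group attached to the carbonyl carbon. Compound 3 stands second highest of the three numbers in this assay; its nearest neighbour is compound 1, and compound 2 lies furthest away, both within the usual scatter.

Compound 4, `COc1cccc(C(=O)C2Sc3nnc(-c4cc(OC)c(OC)c(OC)c4)n3NC2c2ccco2)c1`, is the next step from compound 3: 3-methoxyphenyl in place of 4-phenylphenyl on a carbonyl carbon.

Two measured steps also change the aryl group on this carbonyl carbon. The step of a 2.2-fold higher number from compound 1 to compound 2 (0.33 log units; beyond the scatter) was the only one beyond the scatter, and even it was modest. The step of a 1.3-fold higher number from compound 1 to compound 3 (0.11 log units; within the scatter) stayed within the scatter, as did a 1.7-fold lower number from compound 2 to compound 3 (0.23 log units; within the scatter). Varying this aryl group has therefore moved the numbers only a little in either direction, so compound 4 is expected to stay close to compound 3 in this assay, with the expected step of a 1.0-fold lower number from compound 3 to compound 4 (0.01 log units; within the scatter) lying within the scatter.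

Compound 4 is estimated at 45000 nM in this assay, expected to fall between 20000 nM and 100000 nM.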

Compound 4, half-maximal inhibitory concentration: 84600 nM
Compound 4: middle estimate off by 1.9-fold (0.27 log units), on the low side; the measured number falls inside the stated range.
By their numbers in this assay, from the lowest: compounds 1, 3, 2 and 4 (each within the scatter of the next, the first and the last beyond it).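

In this assay, the 4-phenylphenyl group with its 12 heavy atoms gives way to the 3-methoxyphenyl group with 8, one aromatic ring fewer and the first oxygen on this aryl group, yet the result is only a 1.8-fold higher number from compound 3 to compound 4 (0.27 log units; within the scatter) and stays within the usual scatter. Compound 4 also sits close to the trifluoromethyl-bearing compound, with a 1.1-fold higher number from compound 2 to compound 4 (0.04 log units; within the scatter), while the comparison with the difluoro compound gives a 2.4-fold higher number from compound 1 to compound 4 (0.37 log units; beyond the scatter), which joins a 2.2-fold higher number from compound 1 to compound 2 (0.33 log units; beyond the scatter) as a second modest step beyond the scatter and shows that four quite different aryl groups on this carbonyl carbon still span only a narrow band of weak numbers. Nothing available explains why compound 1 separates from compound 2 and compound 4 while compound 3 stays within the scatter of all the others.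

The compounds shown all keep an aromatic carbon ring on this carbonyl carbon, so it remains open whether an aryl group carrying an amine or a carboxylic acid, or a simple alkyl chain in place of the ring, would move the number further. They also leave open how much the number would respond to changes elsewhere on the shared core.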